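The compounds below may be only part of what the source reports. "The series", "measured", "known", "first", "only" and "open" are said of these compounds alone.

Measured so far in a functional assay for inhibition, read by spectrophotometry, with a stated time of 20 min, tested at 1 mg/mL; on this read-out lower numbers stand for a weaker effect and higher numbers for a stronger effect at the one concentration tested:

Compound 1 `CCC(C)C(C(=O)Nc1ccc(C(C)=O)cc1)N(C(=O)c1ccccc1)S(=O)(=O)c1ccc(C)cc1` gives 18.6%.
Compound 2 `CC(=O)c1ccc(NC(=O)C(C(C)C)N(C(=O)c2ccccc2)S(=O)(=O)c2ccc(C)cc2)cc1` gives 15.6%.
Compound 3 `CCC(C)C(C(=O)Nc1ccc(C(C)=O)cc1)N(C(=O)c1ccccc1)S(=O)(=O)c1ccc([N+](=O)[O-])cc1` gives 28.6%.

Compound 2 differs from compound 1 by one change: hydrogen in place of methyl on a saturated chain carbon, three bonds along the chain from an amide-type nitrogen and a carbonyl carbon. That change gave a number 3 percentage points lower from compound 1 to compound 2 (within the scatter). Compound 3 differs from compound 1 at another place: nitro in place of methyl on an aromatic carbon, and this gave a number 10 percentage points higher from compound 1 to compound 3 (within the scatter). Among the measured compounds shown here, the two values of compound 3 and compound 2 lie further apart than the usual scatter, but no single step joins them.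

Compound 4 `CC(=O)c1ccc(NC(=O)C(C(C)C)N(C(=O)c2ccccc2)S(=O)(=O)c2ccc([N+](=O)[O-])cc2)cc1` has not yet been measured. It carries the same change, made on the core of compound 3 instead of the core of compound 1: hydrogen in place of methyl on a saturated chain carbon, three bonds along the chain from an amide-type nitrogen and a carbonyl carbon. Because the earlier step, a number 3 percentage points lower from compound 1 to compound 2 (within the scatter), stayed within the scatter, the step from compound 3 to compound 4 in this assay is expected to be about as small, a number 3.6 percentage points lower from compound 3 to compound 4 (within the scatter). For the measured compounds named here, only one earlier example supports this expectation, so the range is kept wide. Compound 4 is therefore estimated to give 25%, with a likely span from 14% to 36%.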

Compound 4, a percentage reported as inhibition, at one concentration (the size of the read-out at that concentration, not a potency): 29.8%
Compound 4: the middle estimate sits 4.8 percentage points below what was measured; the range from low to high includes it.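

In this assay, going from sec-butyl to isopropyl on the core that carries the nitro group gave a number 1.2 percentage points higher from compound 3 to compound 4 (within the scatter), which matches what the same change did on the core of compound 1: the same change on two cores in this assay, a number 3 percentage points lower (within the scatter) from compound 1 to compound 2 and a number 1.2 percentage points higher (within the scatter) from compound 3 to compound 4, 4.2 percentage points apart, within the scatter of two such steps. Nitro in place of methyl on the aromatic carbon gave a number 14.2 percentage points higher from compound 2 to compound 4 (beyond the scatter), and this step also agrees with the one seen on the other core: the same change on two cores in this assay, a number 10 percentage points higher (within the scatter) from compound 1 to compound 3 and a number 14.2 percentage points higher (beyond the scatter) from compound 2 to compound 4, 4.2 percentage points apart, within the scatter of two such steps. So within these four compounds, each change behaves about the same on both cores, with the nitro group going with the higher numbers and the chain change making no readable difference; however, this rests on just two cores at one concentration, so it shows neither potency nor a rule for the wider series.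

The compounds shown leave open what a longer chain would do in place of sec-butyl, or an amine or a carboxylic acid in place of the nitro group. They also leave open whether the same agreement between cores would hold for such groups.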